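The source may hold more compounds than are shown below. What is called first, only, known or untested is meant among the compounds shown, and "the series" means these compounds.

For the measured compounds named here, compound 3, `Nc1cccc(/C=C2\SC(=O)N(Cc3ccc(C(F)(F)F)cc3)C2=O)c1`, gives in a functional assay on L1210 cells (Mus musculus) for cytotoxicity, read by cell counting, with a stated time of 2 days (a lower number here means a stronger inhibitor, a higher number a weaker inhibitor), no number but only a limit, > 250000 nM; it is the one compound of the three measured that sits at the limit of > 250000 nM in this assay, at which 1 of the 3 values shown sits. Its two relatives carry the 4-aminophenyl instead: compound 1, `CC(C)(C)c1ccc(CN2C(=O)S/C(=C\c3ccc(N)cc3)C2=O)cc1`, gives in this assay 94000 nM, and compound 2, `Nc1ccc(/C=C2\SC(=O)N(Cc3ccc(F)cc3)C2=O)cc1`, gives 24000 nM. Going by the values given here, the one measured step, a 3.9-fold lower number from compound 1 to compound 2 (0.59 log units; beyond the scatter), concerns a different place and so bears only indirectly on the change at hand.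

Compound 4, `Nc1ccc(/C=C2\SC(=O)N(Cc3ccc(C(F)(F)F)cc3)C2=O)cc1`, differs from compound 3 in a single respect: 4-aminophenyl in place of 3-aminophenyl on a double-bonded chain carbon bound to a double-bonded ring carbon. Because compound 3 shows only a limit, > 250000 nM, the size of the step cannot be computed from the measured numbers; what can be said is that both 4-aminophenyl compounds measured gave numbers rather than limits. Compound 4 is therefore expected to fall within the range spanned by compound 1 and compound 2, so a step of an at least 4.1-fold lower number from compound 3 to compound 4 (0.61 log units; beyond the scatter) toward a stronger inhibitor is estimated. The estimate for compound 4 is 60000 nM, with a range from 15000 nM to 250000 nM.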

Compound 4, half-maximal inhibitory concentration: 6000 nM
Estimate against measurement, compound 4: 10-fold (1.00 log units) above, outside the stated range (below it).
By their numbers in this assay, from the lowest: compound 4; then compound 2; then compound 1. At a limit, above all of these: compound 3.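

Swapping 3-aminophenyl for 4-aminophenyl, with the rest of the molecule unchanged, gives an at least 41-fold lower number from compound 3 to compound 4 (1.61 log units; beyond the scatter) in this assay, the first direct sign that where the amino group sits on this ring matters for cytotoxicity. That step is only a minimum, as compound 3 gives a limit and not a number: the limit of > 250000 nM in this assay, at which 1 of the 4 values shown sits. With 4-aminophenyl kept, trifluoromethyl on an aromatic carbon gives a 4.0-fold lower number from compound 2 to compound 4 (0.60 log units; beyond the scatter) against fluoro and a 16-fold lower number from compound 1 to compound 4 (1.19 log units; beyond the scatter) against tert-butyl, so the order seen earlier between those two groups now extends to a third.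

Only one 3-aminophenyl compound is shown, so it stays open whether the same preference holds with fluoro or tert-butyl. The compounds shown also do not tell whether the amine itself is needed, or whether a hydroxyl or a methoxy group in its place would serve as well.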